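The source may hold more compounds than are shown below. What is called first, only, known or untested is meant among the compounds shown, and "the series" means these compounds.

Working notes on the series, with all numbers read in a functional assay on HeLa cells (Homo sapiens) for antiproliferative activity, read by MTT assay, with a stated time of 72 h; a lower number here means a stronger inhibitor, a higher number a weaker inhibitor. Of the compounds shown here, three have been measured so far. Compound 1 `CCOC(=O)c1csc2nc(CN3CCN(Cc4ccccc4)CC3)c(-c3ccc(C)cc3)n12` gives 38800 nM. Compound 2 `CCOC(=O)c1csc2nc(CN3CCN(C)CC3)c(-c3ccc(Br)cc3)n12` gives 55400 nM. Compound 3 `Cc1ccc(-c2c(CN3CCCCC3)nc3scc(C(=O)O)n23)cc1` gives 7630 nM, the lowest of the three numbers, and its gaps to compound 1 and to compound 2 both lie beyond the scatter. These three compounds differ from one another in more than one place, so no single change can be read from their values.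

Compound 4 `COc1ccc(-c2c(CN3CCCCC3)nc3scc(C(=O)O)n23)cc1` departs from compound 3 in one place only, on an aromatic carbon of a six-membered aromatic ring of carbon only, para to a large group, where 4-methylphenyl becomes 4-methoxyphenyl: methoxy in place of methyl on an aromatic carbon. Among the compounds with values here, the rest of the structure stays the same, and no measured pair isolates this position.

Within the data shown here, with no such pair to go on, the expectation in this assay is no shift beyond the scatter and no firm direction. The expected size of the change is a 1.1-fold lower number from compound 3 to compound 4 (0.04 log units; within the scatter), a small step. Among the measured compounds shown here, for compound 4 the estimated value is 7000 nM, with an expected range of 2500 nM to 20000 nM, kept wide since only three measured compounds support it.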

Compound 4, half-maximal inhibitory concentration: 47400 nM
Compound 4: the middle estimate sits 6.8-fold (0.83 log units) below what was measured; measured number outside the range, above it.
By their numbers in this assay, from the lowest: compound 3; then compounds 1, 4 and 2 (each within the scatter of the next).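

In this assay, within the data shown here, this position is not silent: methoxy in place of methyl on an aromatic carbon, para to a large group, gives a 6.2-fold higher number from compound 3 to compound 4 (0.79 log units; beyond the scatter) and is the first change that can be read on its own. Within this pair, the 4-methylphenyl group goes with the lower number, and the step lies beyond the scatter even though the swap adds only one oxygen and one hydrogen-bond acceptor to the count of atoms. Nothing available on these compounds accounts for the shift, so it stands as an observation on this pair alone.

The compounds shown leave open whether the oxygen itself or the longer methoxy group tracks with the higher number, a question that a hydroxy, ethyl or ethoxy group on the same aromatic carbon would help to separate. They also leave open whether the same step would appear with the piperidine swapped for another amine, or with the carboxylic acid replaced by a primary amide, so the reading holds for this one background only.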